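The compounds below may be only part of what the source reports. "The series", "measured", "known", "first", "only" and "open" are said of these compounds alone.

Working notes on the macrolide series.

Of the compounds shown here, three carry numbers so far. Compound 1 `CC[C@H]1OC(=O)[C@H](C)[C@@H](O[C@H]2C[C@@](C)(OC)[C@@H](OCCCNC(=O)C3CCC3)[C@H](C)O2)[C@H](C)[C@@H](O[C@@H]2O[C@H](C)C[C@H](N(C)C)[C@H]2O)[C@](C)(O)C[C@@H](C)CN(C)[C@H](C)[C@@H](O)[C@]1(C)O`, compound 2 `CC[C@H]1OC(=O)[C@H](C)[C@@H](O[C@H]2C[C@@](C)(OC)[C@@H](O)[C@H](C)O2)[C@H](C)[C@@H](O[C@@H]2O[C@H](C)C[C@H](N(C)CCCNC(C)=O)[C@H]2O)[C@](C)(O)C[C@@H](C)CN(C)[C@H](C)[C@@H](O)[C@]1(C)O` and compound 3 `CC[C@H]1OC(=O)[C@H](C)[C@@H](O[C@H]2C[C@@](C)(OC)[C@@H](O)[C@H](C)O2)[C@H](C)[C@@H](O[C@@H]2O[C@H](C)C[C@H](N(C)C)[C@H]2O)[C@](C)(OC)C[C@@H](C)/C(=N\O)[C@H](C)[C@@H](O)[C@]1(C)OCCCNC(C)=O` were all run in a physicochemical assay for lipophilicity, read by HPLC, measured as chromatographic lipophilicity, at pH 7.4; on this read-out higher numbers stand for higher lipophilicity and lower numbers for lower lipophilicity. In this assay compound 1 gives 2.62, compound 2 gives 2.06 and compound 3 gives 2.94. Compound 1 thus stands second highest of the three: compound 3 lies above it by a gap beyond the scatter, and compound 2 lies below it by a larger gap, also beyond the scatter. For the measured compounds named here, none of these three pairs differs in a single place, so no step within the shared core is isolated by the numbers at hand.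

The next compound in the series is compound 4 `CC[C@H]1OC(=O)[C@H](C)[C@@H](O[C@H]2C[C@@](C)(OC)[C@@H](OCCCNC(=O)c3c(C)nn(C)c3Cl)[C@H](C)O2)[C@H](C)[C@@H](O[C@@H]2O[C@H](C)C[C@H](N(C)C)[C@H]2O)[C@](C)(O)C[C@@H](C)CN(C)[C@H](C)[C@@H](O)[C@]1(C)O`. It differs from compound 1 in one place only: 5-chloro-1,3-dimethyl-1H-pyrazol-4-yl in place of cyclobutyl on a carbonyl carbon. Going by the values given here, no step of this kind has yet been measured within the set, so the direction must be judged from the change alone. The expectation is a modest rise in this assay, with the step from a number 0.33 log units higher from compound 1 to compound 4 (beyond the scatter) set above the scatter but not by much. Accordingly, compound 4 is expected to give about 2.95 in this assay, most plausibly falling between 2.45 and 3.45, with the value of compound 1 2.62 as the anchor for that estimate.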

Compound 4, distribution coefficient: 2.52
The estimate for compound 4 lay 0.43 log units above the measured number; the range from low to high includes it.
By their numbers in this assay, from the lowest: compound 2; then compounds 4 and 1 (each within the scatter of the next); then compound 3.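

In this assay, for the compounds shown here, 5-chloro-1,3-dimethyl-1H-pyrazol-4-yl in place of cyclobutyl on a carbonyl carbon gives a number 0.10 log units lower from compound 1 to compound 4 (within the scatter), the first step that isolates a single place, which the three earlier compounds could not do because no pair among them differed in one place only. At this position, then, a five-membered aromatic ring with 8 heavy atoms and 2 hydrogen-bond acceptors cannot be told apart on this read-out from a four-membered non-aromatic ring with 4 heavy atoms and no hydrogen-bond acceptors, so neither the added heavy atoms nor the added acceptors appear as a separate difference in this pair. Nothing at hand gives a reason for this result.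

One pair cannot separate the contributions of the chlorine, the two methyl groups and the aromatic ring, which enter together and may or may not offset one another. Going by these compounds, it also remains open whether a group of another kind on this carbonyl carbon, such as an amine, a carboxylic acid or a longer chain, would give a step beyond the scatter in this assay, and whether the same exchange would read alike on the core of compound 2 or compound 3.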